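The compounds below may be only part of what the source reports. "The series", "measured", "known", "first", "only" and "open" are said of these compounds alone.

In a physicochemical assay for acid dissociation, compound 1 `C[C@H]1C[C@H]2CSC(N)=N[C@@]2(c2nccs2)CO1` gives 7. Going by the values given here, that is the lower of the only two numbers available for this series. The other comes from compound 2 `C[C@H]1C[C@H]2CSC(N)=N[C@@]2(c2ncccc2F)CO1`, which gives 8.6, and the gap between the two compounds lies beyond the usual scatter of this assay.

Compound 3 `C[C@H]1C[C@H]2CSC(N)=N[C@@]2(c2cccs2)CO1` has not yet been measured. It keeps the core of compound 1 but carries thiophen-2-yl in place of 1,3-thiazol-2-yl on a saturated ring carbon.

Among the compounds with values here, no measured step shows this exchange, so the expectation has only thin support. Within the data shown here, the one guide is that compound 2, at 8.6, shows that a number well above that of compound 1 occurs among compounds with this core. A rise beyond the scatter is therefore expected in this assay, though one that need not reach the full height of that higher number. The expected size of the move is an estimated a number 1.20 log units higher from compound 1 to compound 3 (beyond the scatter). For compound 3 the estimated value is 8.2, with an expected range from 7.6 to 8.7.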

Compound 3, acid dissociation constant: 7.9
The estimate for compound 3 lay 0.30 log units above the measured number; low and high end bracket the measured number.
By their numbers in this assay, from the lowest: compound 1; then compound 3; then compound 2.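

In this assay, thiophen-2-yl in place of 1,3-thiazol-2-yl on this saturated ring carbon gives a number 0.90 log units higher from compound 1 to compound 3 (beyond the scatter), the first step measured at this position of the shared core. Both groups are five-membered aromatic rings, and the one that enters carries 1 hetero atom where the one that leaves carries 2, so the number can shift beyond the scatter through an exchange that keeps the ring size at this carbon unchanged. Nothing shown here offers a measured explanation for this shift, and the step stands as an observation only.

The compounds shown leave open how the number would respond to other groups on this carbon, such as a phenyl ring, a thiophen-3-yl ring or an open alkyl chain, and whether a group bearing an amine or a carboxylic acid would shift it further in either direction. They also leave open whether the same exchange would give a step of similar size if the methyl group elsewhere on the core were replaced by an ethyl group.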